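Replacing 3-Bromophenyl with 4-Fluorophenyl

A few compounds are considered here, and "the series" means these few. Any claim that something is new, unique, unknown or untested is made for them only; others in the source may bear on it.

In a physicochemical assay for lipophilicity, measured as octanol-water partition (on this read-out lower numbers stand for lower lipophilicity and higher numbers for higher lipophilicity), compound 1 (`O=C(COc1cccc2ccccc12)N/N=C/c1ccccc1O`) gives 3.73 while compound 2 (`O=C(COc1cccc2ccccc12)N/N=C/c1cccc(Br)c1`) gives 4.81 and so holds the higher of the two numbers. Compound 3 (`O=C(COc1cccc2ccccc12)N/N=C/c1ccc(F)cc1`) has not been measured yet. It differs from compound 2 in one place (4-fluorophenyl in place of 3-bromophenyl on a carbon with a double bond to nitrogen), with 4-fluorophenyl in place of 3-bromophenyl on a carbon with a double bond to nitrogen.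

For the measured compounds named here, only one measured step bears on this, and it changed the group at that same place. Putting 3-bromophenyl in place of 2-hydroxyphenyl gave a large step (a number 1.08 log units higher from compound 1 to compound 2 (beyond the scatter)). That step shows how far the number can move with a change here, but it involves a different pair of groups, so it sets a scale and not a value. With bromine leaving and fluorine entering, a clear but smaller fall is expected. In this assay the estimated step is a number 0.56 log units lower from compound 2 to compound 3 (beyond the scatter) and it would leave the number between the two measured ones. Compound 3 is expected at 4.25 with an estimated range from 3.9 to 4.6 on this scale.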

Compound 3, partition coefficient: 4.16
Compound 3: the middle estimate sits 0.09 log units above what was measured, and the stated range covers the measured number.
By their numbers in this assay, from the lowest: compound 1; then compound 3; then compound 2.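

In this assay, the exchange of 3-bromophenyl for 4-fluorophenyl gives a number 0.65 log units lower from compound 2 to compound 3 (beyond the scatter), so this position responds even when the two groups match in every computed count: heavy atoms, hydrogen-bond donors, hydrogen-bond acceptors and charge. The replacement of 2-hydroxyphenyl by 4-fluorophenyl gives a number 0.43 log units higher from compound 1 to compound 3 (beyond the scatter), so the three groups tried here form a clear order, with the 2-hydroxyphenyl compound lowest, the 3-bromophenyl compound highest and the 4-fluorophenyl compound in the middle, and every gap in that order lies beyond the usual scatter. No measurement shown here explains why the numbers fall in this order.

The halogen and its location on the ring change together between these two compounds, so the compounds shown cannot tell how much of the step belongs to each change. On these data alone, it also remains open how the number would respond at this position to a phenyl ring carrying chlorine, an amine or a carboxylic acid, or to a longer chain in place of the ring.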